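Halogenated aryl ketones on a trimethoxyphenyl pyrazole core

The source may report more compounds than this note shows. Statements on the series, on what has been measured and on what is new or still open speak of the compounds shown alone.

Compound 1 `COc1cc(-c2cc(/C=C/C(=O)c3ccc(N)cc3)[nH]n2)cc(OC)c1OC`: 3630 nM
Compound 2 `COc1cc(-c2cc(/C=C/C(=O)c3ccc(Cl)c(Cl)c3)[nH]n2)cc(OC)c1OC`: 31400 nM
Compound 3 `COc1ccc(C(=O)/C=C/c2cc(-c3cc(OC)c(OC)c(OC)c3)n[nH]2)cc1`: 3400 nM

In a functional assay on HCC 2998 cells (Homo sapiens) for inhibition, read by sulforhodamine B assay, with a stated time of 48 h (a higher number here means a weaker inhibitor of growth, a lower number a stronger inhibitor of growth), compound 3 gives the lowest of the three numbers, though compound 1 sits within the scatter of it; only compound 2 stands clearly apart. Compound 4 `COc1cc(-c2cc(/C=C/C(=O)c3ccc(F)c(F)c3)[nH]n2)cc(OC)c1OC` differs from compound 3 by 3,4-difluorophenyl in place of 4-methoxyphenyl on a carbonyl carbon. Within the data shown here, the closest precedent is a 9.2-fold lower number from compound 2 to compound 3 (0.97 log units; beyond the scatter), where a 3,4-dichlorophenyl in the same place gave a markedly higher number; an 8.7-fold higher number from compound 1 to compound 2 (0.94 log units; beyond the scatter) points the same way. A 3,4-difluorophenyl is a related halogen pattern, so a higher number is expected for compound 4, estimated as a 3.5-fold higher number from compound 3 to compound 4 (0.55 log units; beyond the scatter), a value of about 12000 nM with a range from 4000 nM to 40000 nM.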

Compound 4, concentration for total growth inhibition: 34100 nM
Estimate against measurement, compound 4: 2.8-fold (0.45 log units) below, and the stated range covers the measured number.
By their numbers in this assay, from the lowest: compounds 3 and 1 (each within the scatter of the next); then compounds 2 and 4 (each within the scatter of the next).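

In this assay, the 3,4-difluorophenyl group on the carbonyl carbon behaves like the 3,4-dichlorophenyl group, with a 1.1-fold higher number from compound 2 to compound 4 (0.04 log units; within the scatter). The higher number seen with one halogen pattern therefore appears with a second, as shown by a 10-fold higher number from compound 3 to compound 4 (1.00 log units; beyond the scatter) and by a 9.4-fold higher number from compound 1 to compound 4 (0.97 log units; beyond the scatter). Among these four compounds, both dihalogenated rings stand apart from the 4-methoxyphenyl and 4-aminophenyl rings, and no compound goes against this.

No supporting evidence is available to explain this shared behaviour. The compounds shown leave open how a ring carrying only one fluorine, or a 4-dimethylaminophenyl group, would fare here.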